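The source may report more compounds than this note shows. Statements on the series, on what has been measured and on what is new or still open speak of the compounds shown alone.

Of the compounds shown here, two have been measured so far. Compound 1 `COc1ccnc(NC[C@@H]2C[C@@H](OCC(=O)NC[C@H](NS(=O)(=O)c3c(C)cc(C)cc3C)C(=O)O)CN2C(=O)OCc2ccccc2)c1` gives 1.1 nM in an assay on a protein complex for inhibition of integrin alpha-5/beta-1 (Homo sapiens), read by ELISA; on this read-out lower numbers stand for stronger inhibition and higher numbers for weaker inhibition. Compound 2 `O=C(CO[C@@H]1C[C@@H](CNc2ccccn2)N(C(=O)OCc2ccccc2)C1)NC[C@H](NS(=O)(=O)c1ccccc1)C(=O)O` gives 86 nM in this assay, the higher of the two numbers and therefore the weaker inhibitor, and the gap between them lies well beyond the scatter of repeated measurements. The two compounds differ in more than one place, so the gap cannot be tied to a single change; compound 1 carries a methoxy group on its pyridine ring and a 2,4,6-trimethylphenyl on the sulfonyl sulfur, whereas compound 2 has neither.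

Compound 3 `Cc1cc(C)c(S(=O)(=O)N[C@@H](CNC(=O)CO[C@@H]2C[C@@H](CNc3ccccn3)N(C(=O)OCc3ccccc3)C2)C(=O)O)c(C)c1` takes one of these changes on its own. It differs from compound 2 by 2,4,6-trimethylphenyl in place of phenyl on a sulfonyl sulfur only, so that it shares the trimethylphenyl sulfonyl part with compound 1 while keeping the plain pyridine of compound 2. Because compound 1 gives 1.1 nM and compound 2 gives 86 nM, a large share of that gap is expected to follow the sulfonyl change, and the step from compound 2 to compound 3 is expected to be a clear fall in the number, a 17-fold lower number from compound 2 to compound 3 (1.24 log units; beyond the scatter). In this assay compound 3 is estimated at 5 nM, with a range from 1.5 nM to 20 nM.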

Compound 3, half-maximal inhibitory concentration: 3.7 nM
Beside the measured number, compound 3's estimate is 1.4-fold (0.13 log units) above it; the measured number falls inside the stated range.
By their numbers in this assay, from the lowest: compound 1; then compound 3; then compound 2.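

On the sulfonyl sulfur, 2,4,6-trimethylphenyl in place of phenyl gives a 23-fold lower number from compound 2 to compound 3 (1.37 log units; beyond the scatter) in this assay, so this single change now accounts for the larger part of the gap between compound 1 and compound 2. The remaining change can also be read alone: hydrogen in place of methoxy on an aromatic carbon gives a 3.4-fold higher number from compound 1 to compound 3 (0.53 log units; beyond the scatter), a smaller step that still lies beyond the scatter, so the methoxy group also counts when the sulfonyl sulfur carries 2,4,6-trimethylphenyl. No measurement shown here explains why either change moves the number.

On these data alone, it remains open whether methoxy would bring a step of the same size with plain phenyl on the sulfonyl sulfur, since each step has so far been read with 2,4,6-trimethylphenyl present. As far as these compounds go, it is also open how other groups on the sulfonyl sulfur, such as naphthyl or cyclohexyl, or an ethoxy group or a chlorine atom in place of methoxy on the aromatic carbon, would compare with these compounds.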